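The compounds below may be only part of what the source reports. "The series", "measured", "known", "first", "only" and "open" are said of these compounds alone.

- compound 1 `COc1cc(OC)c(OC)cc1/C=C/C(=O)c1cc(OC(C)=O)ccc1OC(C)=O`: 63700 nM
- compound 2 `COc1cc(OC)c(OC)cc1/C=C/C(=O)c1ccc(O)cc1O`: 33800 nM

Both values come from a functional assay on MCF7 cells (Homo sapiens) for inhibition, read by MTT assay, with a stated time of 72 h; a higher number here means a weaker inhibitor, a lower number a stronger inhibitor. Within the data shown here, compound 2 has only one measured neighbour, compound 1, and the two lie within the usual scatter of each other, so the data do not separate them. Both sit in the same broad range, and nothing more can be read from two compounds.

The next compound to be tested is compound 3 `COc1cc(OC)c(OC)cc1/C=C/C(=O)c1cc(O)ccc1O`. It keeps the core of compound 2 and carries 2,5-dihydroxyphenyl in place of 2,4-dihydroxyphenyl on a carbonyl carbon. Among the measured compounds shown here, the series offers no measured step for this change, so its size cannot be read from the data. The expectation rests only on the close spread between compound 1 at 63700 nM and compound 2 at 33800 nM.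

A small move toward a stronger inhibitor is expected, though it may not clear the scatter. The expected step is a 1.7-fold lower number from compound 2 to compound 3 (0.23 log units; within the scatter). In this assay the estimated value for compound 3 is 20000 nM, with an expected range of 6000 nM to 55000 nM.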

Compound 3, half-maximal inhibitory concentration: > 150000 nM
Compound 3: only a limit was reported; the forecaster's own chance of this, stated with the estimate: 7%; middle value at least 7.5-fold (0.87 log units) from the limit.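

Among these compounds, with 2,5-dihydroxyphenyl in place of 2,4-dihydroxyphenyl on a carbonyl carbon, this assay gives the first step that clears the scatter: an at least 4.4-fold higher number from compound 2 to compound 3 (0.64 log units; beyond the scatter) marks this position as sensitive to where the hydroxyl groups are placed. Compound 2 and compound 3 have the same atoms joined differently, and the two groups match in their counted features, so a rearrangement alone is enough to produce this loss of inhibition, with nothing added or removed. For compound 3, the reported figure is a limit and not a number, so the step gives only a minimum size: the limit of > 150000 nM in this assay, at which 1 of the 3 values shown sits.

Going by these compounds, the true distance between compound 2 and compound 3 remains open. It is also unknown whether the 2,4-dihydroxyphenyl arrangement needs both hydroxyl groups, or whether a methoxy group, an amine or a carboxylic acid in place of either hydroxyl would hold or lose inhibition on the shared core.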